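The source may hold more compounds than are shown below. What is called first, only, known or untested is meant among the compounds shown, and "the series" means these compounds.

In a functional assay on MCF7 cells (Homo sapiens) for antiproliferative activity, read by MTT assay, with a stated time of 48 h (a lower number here means a stronger inhibitor, a higher number a weaker inhibitor), three compounds that share one core and the (2-(dimethylamino)ethyl)amino group have been measured. Compound 1 `COc1cccc(C(=O)Nc2cc3cnc(NCCN(C)C)cc3n(C)c2=O)c1` gives 43300 nM, compound 2 `CN(C)CCNc1cc2c(cn1)cc(NC(=O)c1ccc(Cl)cc1)c(=O)n2C` gives 3090 nM, and compound 3 `COc1ccc(C(=O)Nc2cc3cnc(NCCN(C)C)cc3n(C)c2=O)cc1` gives 37300 nM. Compound 3 therefore stands level with compound 1, with a 1.2-fold lower number from compound 1 to compound 3 (0.06 log units; within the scatter), and well on the weak side of compound 2, with a 12-fold higher number from compound 2 to compound 3 (1.08 log units; beyond the scatter).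

Compound 4 `COc1ccc(C(=O)Nc2cc3cnc(N4CCN(C)CC4)cc3n(C)c2=O)cc1` keeps the 4-methoxyphenyl on the carbonyl carbon and changes the other end of the molecule: 4-methylpiperazin-1-yl in place of (2-(dimethylamino)ethyl)amino on an aromatic carbon, next to the ring nitrogen (4-methylpiperazin-1-yl in place of (2-(dimethylamino)ethyl)amino on an aromatic carbon).

Among the measured compounds shown here, none of the measured steps touches this place. All three vary only the group on the carbonyl carbon, and the large one, a 14-fold lower number from compound 1 to compound 2 (1.15 log units; beyond the scatter), involves the chloro compound, not the methoxy group that compound 4 retains. The data therefore give no size for this exchange, and no step beyond the scatter is expected, though with wide uncertainty in both directions. The step expected is a 1.2-fold lower number from compound 3 to compound 4 (0.09 log units; within the scatter). Compound 4 is estimated at 30000 nM, with an expected range from 9000 nM to 90000 nM.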

Compound 4, half-maximal inhibitory concentration: 35400 nM
Estimate against measurement, compound 4: 1.2-fold (0.07 log units) below; the measured number falls inside the stated range.
By their numbers in this assay, from the lowest: compound 2; then compounds 4, 3 and 1 (each within the scatter of the next).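

In this assay, among the compounds shown here, the exchange of (2-(dimethylamino)ethyl)amino for 4-methylpiperazin-1-yl gives the first reading at this position, on the aromatic carbon next to the ring nitrogen, with a 1.1-fold lower number from compound 3 to compound 4 (0.02 log units; within the scatter). With the 4-methoxyphenyl kept on the carbonyl carbon, the open chain with its hydrogen-bond donor can therefore be replaced by a six-membered non-aromatic ring with no hydrogen-bond donor, without a step beyond the scatter in this assay. No measurement shown here offers an explanation for how closely these two compounds agree.

For the compounds shown here, this single pair leaves open whether the exchange would be equally silent alongside the 4-chlorophenyl group of compound 2, the only group here tied to a large step, as in a 14-fold lower number from compound 1 to compound 2 (1.15 log units; beyond the scatter). It also leaves open how other groups at this position would read, such as morpholin-4-yl, a primary amine or a longer chain like (3-(dimethylamino)propyl)amino, so the tolerance seen with 4-methylpiperazin-1-yl cannot yet be extended beyond that one group.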